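The source may report more compounds than this note shows. Statements on the series, on what has been measured and on what is new or still open speak of the compounds shown alone.

Working notes on the series, read in an ADME assay on microsomes from liver (Homo sapiens) for pharmacokinetics, read by LC-MS, with a stated time of 60 min, tested at 1 uM; a lower number here means slower removal, a higher number faster removal of the compound:

Compound 1 `CCC(=O)N1CCC(S(=O)(=O)c2ccc(CNC(=O)N3Cc4ccncc4C3)cc2)CC1`: 11 mL/min/kg
Compound 2 `O=C(NCc1ccc(S(=O)(=O)C2CCN(C3COC3)CC2)cc1)N1Cc2ccncc2C1`: 10 mL/min/kg
Compound 3 `O=C(NCc1ccc(S(=O)(=O)N2CCOCC2)cc1)N1Cc2ccncc2C1`: 9 mL/min/kg

Compound 3, at 9 mL/min/kg, stands within the scatter of both other compounds, so the three values do not separate in this assay. The next compound is compound 4 `CN1CCN(S(=O)(=O)c2ccc(CNC(=O)N3Cc4ccncc4C3)cc2)CC1`, with 4-methylpiperazin-1-yl in place of morpholin-4-yl on a sulfonyl sulfur.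

Two measured steps change the group on the sulfonyl sulfur: a 1.2-fold lower number from compound 1 to compound 3 (0.09 log units; within the scatter), and a 1.1-fold lower number from compound 2 to compound 3 (0.05 log units; within the scatter). A third step, a 1.1-fold lower number from compound 1 to compound 2 (0.04 log units; within the scatter), changes only the group on an amine nitrogen in a ring. All three are small, and the group on the sulfonyl sulfur has so far made no measurable difference. However, no measured compound carries 4-methylpiperazin-1-yl, so this group itself is untested and the upper side of the estimate is left wider.

No step beyond the scatter is therefore expected in this assay. The estimated step is a 1.2-fold higher number from compound 3 to compound 4 (0.09 log units; within the scatter). For compound 4 the expected value is 11 mL/min/kg, with an estimated range from 7 mL/min/kg to 19 mL/min/kg.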

Compound 4, clearance: 9 mL/min/kg
The estimate for compound 4 lay 1.2-fold (0.09 log units) above the measured number; the range from low to high includes it.
By their numbers in this assay, from the lowest: compounds 3, 4, 2 and 1 (each within the scatter of the next).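

Going by these compounds alone, the step of no change at the digits printed from compound 3 to compound 4 (within the scatter) lies within the scatter, so 4-methylpiperazin-1-yl, the one group on a sulfonyl sulfur not covered by the earlier compounds, reads the same as morpholin-4-yl in this assay. Within the data shown here, the two remaining steps, a 1.1-fold lower number from compound 2 to compound 4 (0.05 log units; within the scatter) and a 1.2-fold lower number from compound 1 to compound 4 (0.09 log units; within the scatter), also stay within the scatter, which extends the flat picture at this position to four different groups on the sulfonyl sulfur, with no compound among them separated from any other. Nothing shown accounts for this flat reading, and no cause can be assigned to any of these groups.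

Going by these compounds, whether an open-chain dimethylamino group, a carboxylic acid or a primary amine on a longer chain at the sulfonyl sulfur would step beyond the scatter remains open. Also open, on these data alone, is whether any change to the shared core, rather than at this position, would move the number in this assay at all.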